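This account rests on a few compounds, and the source may have more. Where it says the series, first, only, none or still open, it means among the compounds named here.

Measured compounds in the series:
compound 1 `CCOC(=O)c1[nH]c2cc(Cl)ccc2c1/C=N/NC(=O)CCc1ccccc1` — in an assay for inhibition of Polyunsaturated fatty acid lipoxygenase ALOX15 (Homo sapiens), with a stated time of 8 min (on this read-out higher numbers stand for weaker inhibition and lower numbers for stronger inhibition), compound 1 gives > 10000 nM
compound 2 `CCOC(=O)c1[nH]c2cc(Cl)ccc2c1/C=N/NC(=O)CCC(C)C` — compound 2 gives > 10000 nM
compound 3 `CCOC(=O)c1[nH]c2cc(Cl)ccc2c1/C=N/NC(=O)COc1ccc([N+](=O)[O-])cc1` — compound 3 gives > 10000 nM

Each of these three values is a limit of this assay and not a number. Compound 2 thus stands at the limit, as do the other two, and no order among the three can be read from what is shown. The steps a step that the two limits leave unreadable from compound 1 to compound 2, a step that the two limits leave unreadable from compound 1 to compound 3 and a step that the two limits leave unreadable from compound 2 to compound 3 are accordingly unreadable in size, because every value sits at the limit of > 10000 nM in this assay, at which 3 of the 3 values shown sit. Within the measured set, nothing shows whether exchanging the group on the chain carbon beside the hydrazide carbonyl moves the read-out at all.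

Compound 4 `CCOC(=O)c1[nH]c2cc(Cl)ccc2c1/C=N/NC(=O)CCCOc1ccc(Cl)cc1Cl` is not yet measured. It differs from compound 2 by (2,4-dichlorophenoxy)methyl in place of isopropyl on a saturated chain carbon, two bonds along the chain from a carbonyl carbon. Going by the values given here, none of the measured steps bears readably on this change, since each of them joins two limits; the phenyl of compound 1, the isopropyl of compound 2 and the 4-nitrophenoxy of compound 3 all leave the read-out at the limit. The step from compound 2 to compound 4 is therefore expected to be a number no higher from compound 2 to compound 4 (the limit leaves the size open), with a further limit the most likely outcome. For compound 4 the estimate in this assay is 10000 nM, with a range from 2500 nM to 40000 nM.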

Compound 4, half-maximal inhibitory concentration: > 10000 nM
Compound 4: only a limit was reported (the forecaster's own chance of this, stated with the estimate: 70%); the middle value lies on the limit itself.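

In this assay compound 4 gives > 10000 nM, which is a limit and not a number. The steps joining compound 4 to compound 1 and compound 2 cannot be read, because all the values rest on the same limit: the limit of > 10000 nM in this assay, at which 4 of the 4 values shown sit.

The compounds shown leave open whether exchanging the group on the chain changes the read-out at all.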